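The compounds below may be only part of what the source reports. "The series", "measured", "known", "first", "only" and "open" are said of these compounds alone.

Working notes on the series. Compound 1 `CCC[S+]([O-])c1sc2nc(-c3cccs3)cc(C(=O)O)c2c1N` in an assay for inhibition of 15-hydroxyprostaglandin dehydrogenase [NAD(+)] (Homo sapiens), read by fluorescence, with a stated time of 15 min, in the presence of a further agent that is not named here (on this read-out higher numbers stand for weaker inhibition and lower numbers for stronger inhibition), gives 71 nM and stands highest of the two numbers recorded. Compound 2 `CCCCS(=O)(=O)c1sc2nc(-c3nccs3)cc(-c3cnc(C)n3C)c2c1N` in this assay gives 32 nM, a lower number, and the gap to compound 1 is beyond the scatter. Compound 3 `CCC[S+]([O-])c1sc2nc(-c3cccs3)cc(C(=O)N(C)C)c2c1N` is unmeasured; it differs from compound 1 by dimethylamino in place of hydroxy on a carbonyl carbon. For the measured compounds named here, no pair of measured compounds shows this change, so its effect cannot be read from the data. The step from compound 1 to compound 3 is expected to be a 1.4-fold higher number from compound 1 to compound 3 (0.15 log units; within the scatter), with direction uncertain. Compound 3 is estimated at 100 nM, within 25 nM to 400 nM.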

Compound 3, half-maximal inhibitory concentration: 14.7 nM
The estimate for compound 3 lay 6.8-fold (0.83 log units) above the measured number, outside the stated range (below it).
By their numbers in this assay, from the lowest: compound 3; then compound 2; then compound 1.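

Replacing hydroxy with dimethylamino on the carbonyl carbon, which reads as carboxy to dimethylcarbamoyl, gives a 4.8-fold lower number from compound 1 to compound 3 (0.68 log units; beyond the scatter) in this assay. A free carboxy group is therefore not needed at this position for a low number on the shared core, and its replacement here gives stronger inhibition. No supporting measurement explains this step.

This single pair leaves open how amino, methylamino or pyrrolidinyl on the same carbonyl carbon would compare with dimethylamino. It also leaves open whether a methyl ester would follow the amide.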